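Swapping chloro for methyl on a maximal compound

A few compounds are considered here, and "the series" means these few. Any claim that something is new, unique, unknown or untested is made for them only; others in the source may bear on it.

So far three compounds sharing one core have been tested in a functional assay on the whole organism with Rattus norvegicus as the target, at a dose of 1 mg/kg by the oral route; a higher number here means a stronger effect of the compound at the dose given, a lower number a weaker effect. Compound 1 `O=C(Nc1nn[nH]n1)c1cc(Cl)cc(-c2ccccc2)n1` gives 40%. Compound 2 `CCCc1ccc(-c2cc(Cl)cc(C(=O)Nc3nn[nH]n3)n2)cc1` gives 78%, and compound 3 `Nc1ccc(-c2cc(Cl)cc(C(=O)Nc3nn[nH]n3)n2)cc1` gives 100%, the highest of the three; the rise a number 22 percentage points higher from compound 2 to compound 3 (beyond the scatter) and the rise a number 60 percentage points higher from compound 1 to compound 3 (beyond the scatter) both exceed the scatter. Compound 4 `Cc1cc(C(=O)Nc2nn[nH]n2)nc(-c2ccc(N)cc2)c1` differs from compound 3 in one place: methyl in place of chloro on an aromatic carbon. Within the data shown here, every measured step, including a number 38 percentage points higher from compound 1 to compound 2 (beyond the scatter), changes the group on the phenyl ring, not this position, so no measured step bears on the change. Compound 3 already sits at the top of the scale, so compound 4 is expected to come out at 85%, between 55% and 100%, a step of a number 15 percentage points lower from compound 3 to compound 4 (beyond the scatter).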

Compound 4, a percentage reported as inhibition, in the whole organism at one dose (the size of the read-out at that dose, not a potency): 75%
Compound 4: the middle estimate sits 10 percentage points above what was measured, within the range that was stated.
By their numbers in this assay, from the lowest: compound 1; then compounds 4 and 2 (each within the scatter of the next); then compound 3.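

Among these compounds, this is the first measured change at the position opposite the ring nitrogen, and it shows that the group there matters in this assay: methyl in place of chloro gives a number 25 percentage points lower from compound 3 to compound 4 (beyond the scatter), a step beyond the scatter. The two groups have the same heavy-atom count and neither adds a hydrogen-bond donor or acceptor, so those counts do not separate them. Nothing measured here explains the drop.

Still open, from the compounds shown here alone, is whether the loss reflects something particular to chloro or to methyl, which a bromo or methoxy group at this position could begin to show. Also open, going by these compounds, is whether the same swap would cost as much with the propyl group of compound 2 on the phenyl ring.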